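The source may hold more compounds than are shown below. What is called first, only, known or untested is meant among the compounds shown, and "the series" means these compounds.

Compound 1, with the structure `COc1ccc([C@H](C)NC(=O)Cn2nnc3ccccc3c2=O)cc1`, is the starting point of this small set. In an ADME assay on microsomes from liver (Homo sapiens) for metabolic stability (a higher number here means faster removal of the compound, a lower number slower removal), compound 1 gives 13 mL/min/kg. Compound 2, with the structure `COc1ccc([C@H](C)NC(=O)Cn2nnc3ccccc3c2=O)c(OC)c1`, differs from compound 1 by methoxy in place of hydrogen on an aromatic carbon. In this assay compound 2 gives 24 mL/min/kg. The change made a step of a 1.8-fold higher number from compound 1 to compound 2 (0.27 log units; within the scatter).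

Compound 3, with the structure `C[C@H](NC(=O)Cn1nnc2ccccc2c1=O)c1ccc(OC(F)F)cc1`, differs from compound 1 by difluoromethyl in place of methyl on an oxygen on an aromatic ring. For compound 3 this assay gives only a limit, < 9.9 mL/min/kg, and not a number. Among the compounds with values here, compound 3 is the one whose value sits at the limit of < 9.9 mL/min/kg in this assay, at which 1 of the 3 values shown sits. The step from compound 1 is an at least 1.3-fold lower number from compound 1 to compound 3 (0.11 log units; that floor lies within the scatter).

Compound 4, with the structure `COc1cccc2nnn(CC(=O)N[C@@H](C)c3ccc(OC(F)F)cc3)c(=O)c12`, has not yet been measured. It differs from compound 3 by methoxy in place of hydrogen on an aromatic carbon. This is the same kind of change that was made from compound 1 to compound 2, but not the same change: there the group entered on an aromatic carbon of a six-membered aromatic ring of carbon only, ortho to a large group and meta to a methoxy group, whereas here it enters on a ring that is part of a fused or bridged system of two rings, ortho to a fused ring and meta to a fused ring. The two cores differ by difluoromethyl in place of methyl on an oxygen on an aromatic ring.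

For compound 4 a step of an at least 1.2-fold higher number from compound 3 to compound 4 (0.08 log units; that floor lies within the scatter) is expected in this assay, next to the earlier 1.8-fold higher number from compound 1 to compound 2 (0.27 log units; within the scatter), resting on that single measured instance of the change and on the limit given for compound 3. The estimate for compound 4 in this assay is therefore 12 mL/min/kg, expected between 6 mL/min/kg and 25 mL/min/kg.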

Compound 4, clearance in the Homo sapiens assay: < 9.9 mL/min/kg
Compound 4 ended at the assay's limit (the forecaster's own chance of this, stated with the estimate: 35%); middle value at least 1.2-fold (0.08 log units) away from the limit.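

In the Homo sapiens assay compound 3 gives < 9.9 mL/min/kg, which is a limit and not a number. Within the data shown here, in the Homo sapiens assay compound 4 gives < 9.9 mL/min/kg, which is also a limit and not a number, so no step between compound 3 and compound 4 can be read. The compounds shown leave open how fast either compound is actually removed, and whether methoxy in place of hydrogen on an aromatic carbon changes clearance at all in this pair. In a physicochemical assay for solubility, read by HPLC, in phosphate buffer, with a stated time of 16 h, at pH 6.8 (a higher number here means a more soluble compound, a lower number a less soluble compound), compound 3 gives 2400 nM and compound 4 gives 9600 nM. In the physicochemical assay the change is a 4.0-fold higher number from compound 3 to compound 4 (0.60 log units; beyond the scatter).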